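From an allyl ester to a neopentyl amide

This account rests on a few compounds, and the source may have more. Where it says the series, first, only, none or still open, it means among the compounds named here.

Measured compounds:
compound 1 `CCNC(=O)c1ccc2[nH]c(NC(=O)OC)nc2c1`: 10000 nM
compound 2 `COC(=O)Nc1nc2cc(C(=O)OCC3CC3)ccc2[nH]1`: 6900 nM
compound 3 `C=CCOC(=O)c1ccc2[nH]c(NC(=O)OC)nc2c1`: > 10000 nM

Three compounds share one core and differ only in the group on the carbonyl carbon attached to the aromatic ring. In a functional assay on L1210 cells (Mus musculus) for inhibition (a higher number here means a weaker inhibitor, a lower number a stronger inhibitor), compound 1 gives 10000 nM and compound 2 gives 6900 nM, a pair that differ by a 1.4-fold lower number from compound 1 to compound 2 (0.16 log units; within the scatter). For compound 3 the value > 10000 nM is a limit of the assay, not a number; its standing can be given only as the limit of > 10000 nM in this assay, at which 1 of the 3 values shown sits, and compared with compound 2 it shows an at least 1.4-fold higher number from compound 2 to compound 3 (0.16 log units; that floor lies within the scatter).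

Compound 4 `COC(=O)Nc1nc2cc(C(=O)NCC(C)(C)C)ccc2[nH]1` has not yet been measured. Relative to compound 3 the change is neopentylamino in place of allyloxy on a carbonyl carbon. The step that bears on it most directly runs the other way: a number no lower from compound 1 to compound 3 (the limit leaves the size open), where the limit hides how much the ester lost. Compound 4 returns to an amide like compound 1, with neopentylamino in place of ethylamino, and the amide-to-ester comparison in a 1.4-fold lower number from compound 1 to compound 2 (0.16 log units; within the scatter) suggests that the substituent on this carbonyl carbon moves the number little when both values are readable. Compound 4 is therefore expected to give 10000 nM, with a range from 4000 nM to 25000 nM. The implied step a number no higher from compound 3 to compound 4 (the limit leaves the size open) is an expectation whose size cannot be fixed from a limit, and it may itself end as a limit.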

Compound 4, half-maximal inhibitory concentration: 8600 nM
Estimate against measurement, compound 4: 1.2-fold (0.07 log units) above; measured number inside the range.
By their numbers in this assay, from the lowest: compounds 2, 4 and 1 (each within the scatter of the next).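

In this assay, within the data shown here, tert-butyl in place of methyl on the saturated chain carbon bound to the amide-type nitrogen gives a 1.2-fold lower number from compound 1 to compound 4 (0.07 log units; within the scatter), so the first comparison of two amides at this carbonyl carbon shows that the larger neopentylamino group does not separate compound 4 from compound 1. Neopentylamino in place of cyclopropylmethoxy gives a 1.2-fold higher number from compound 2 to compound 4 (0.10 log units; within the scatter), so across compounds 1, 2 and 4, two amides and an ester with differently shaped chains show no step beyond the scatter. The step against the allyl ester is an at least 1.1-fold lower number from compound 3 to compound 4 (0.06 log units; that floor lies within the scatter), but this gives only a floor, and the true size stays unknown since compound 3 stands only as a limit of the assay: the limit of > 10000 nM in this assay, at which 1 of the 4 values shown sits.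

The compounds shown leave open whether any group on this carbonyl carbon can move the number beyond the scatter, for example a carboxylic acid in place of the ester, a chain ending in an amine, or a benzylamino group. They also leave open where compound 3 would stand if it gave a readable number.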